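Straightening the Side Chain: Branched to Linear Butyl

The source may hold more compounds than are shown below. What is called first, only, known or untested is meant among the compounds shown, and "the series" means these compounds.

Compound 1 `CCNc1nc(Cl)nc(N[C@H](C)c2ccccc2)n1` gives 2690 nM in an ADME assay on the whole organism for inhibition, with Echinochloa crus-galli var. formosensis as the target, with a stated time of 4 days; on this read-out higher numbers stand for weaker inhibition and lower numbers for stronger inhibition.
Compound 2 `CC[C@@H](C)Nc1nc(Cl)nc(N[C@@H](C)c2ccccc2)n1` gives 7410 nM in this assay.
Compound 3 `CC[C@@H](C)Nc1nc(Cl)nc(N[C@H](C)c2ccccc2)n1` gives 4570 nM in this assay.

Compound 2 carries the highest number of the three; its gap to compound 3 lies within the scatter, while its gap to compound 1 lies beyond it. Compound 4 `CCCCNc1nc(Cl)nc(N[C@@H](C)c2ccccc2)n1` differs from compound 2 by butyl in place of sec-butyl on a nitrogen on an aromatic ring. Among the compounds with values here, two measured steps touch this change only loosely. The step of a 1.7-fold higher number from compound 1 to compound 3 (0.23 log units; within the scatter) shows that adding carbon to the side chain stays within the scatter, and a 1.6-fold lower number from compound 2 to compound 3 (0.21 log units; within the scatter) shows the same for a redrawn stereocentre, a pair that (the fact that compounds 2 and 3 differ only in the configuration as drawn). Within the data shown here, neither step swaps a branched chain for a straight one, so no direct precedent exists. Compound 4 is therefore expected to show a 1.2-fold lower number from compound 2 to compound 4 (0.09 log units; within the scatter), a shift within the scatter. The estimate for compound 4 is 6000 nM, with a range from 3000 nM to 15000 nM.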

Compound 4, half-maximal inhibitory concentration: 12900 nM
Compound 4: middle estimate off by 2.2-fold (0.33 log units), on the low side; the range from low to high includes it.
By their numbers in this assay, from the lowest: compounds 1, 3, 2 and 4 (each within the scatter of the next, the first and the last beyond it).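

Within the data shown here, replacing sec-butyl with butyl on the nitrogen gives a 1.7-fold higher number from compound 2 to compound 4 (0.24 log units; within the scatter) in this assay, the first direct comparison of a branched and a straight chain at this position. This swap also removes the stereocentre on the side chain, yet the change stays within the scatter, so these two chains cannot be told apart in this pair. No measured finding shown here explains this result. Still open, from the compounds shown here alone, is whether a longer chain, such as hexyl, on this nitrogen would also stay within the scatter.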